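Benzyl for thiophenyl on the shared core

A few compounds are considered here, and "the series" means these few. Any claim that something is new, unique, unknown or untested is made for them only; others in the source may bear on it.

Compound 1 `CCOC(=O)c1cnc(-n2nc(C)cc2C)nc1NN1C(=O)C=C(C)C1=O`: 10000 nM
Compound 2 `CCOC(=O)c1cnc(-c2ccsc2)nc1NN1C(=O)C=C(C)C1=O`: 100 nM

Compound 2 gives the lower of the two numbers in a functional assay on Jurkat cells for inhibition of nuclear factor NF-kappa-B complex (Homo sapiens); on this read-out higher numbers stand for weaker inhibition and lower numbers for stronger inhibition; compound 1 stands apart by a 100-fold lower number from compound 1 to compound 2 (2.00 log units; beyond the scatter). Compound 3 `CCOC(=O)c1cnc(Cc2ccccc2)nc1NN1C(=O)C=C(C)C1=O` differs from compound 2 by benzyl in place of thiophen-3-yl on an aromatic carbon. For the measured compounds named here, no measured step covers this exchange: the only step known, from compound 1 to compound 2, swaps one five-membered ring for another, so it merely shows that this position moves the number strongly. The author therefore expects a moderate rise for compound 3, a 10-fold higher number from compound 2 to compound 3 (1.00 log units; beyond the scatter), with wide uncertainty. The estimate for compound 3 in this assay is 1000 nM, within 150 nM to 8000 nM.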

Compound 3, half-maximal inhibitory concentration: 7000 nM
The estimate for compound 3 lay 7.0-fold (0.85 log units) below the measured number; the measured number falls inside the stated range.
By their numbers in this assay, from the lowest: compound 2; then compounds 3 and 1 (each within the scatter of the next).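

In this assay the exchange of thiophen-3-yl for benzyl gives a 70-fold higher number from compound 2 to compound 3 (1.85 log units; beyond the scatter), so a second aromatic ring at this carbon does not by itself keep the low number. Benzyl and 3,5-dimethyl-1H-pyrazol-1-yl lie within the scatter of each other, with a 1.4-fold lower number from compound 1 to compound 3 (0.15 log units; within the scatter), which leaves thiophen-3-yl as the only one of the three groups giving the low number. No evidence at hand accounts for this difference.

From the compounds shown here alone, whether the low number belongs to thiophen-3-yl alone remains open. So does what a phenyl group joined directly to this carbon, or an amine here, would give.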